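Methyl addition on the aryl ketone of oxadiazole series

The source may hold more compounds than are shown below. What is called first, only, known or untested is meant among the compounds shown, and "the series" means these compounds.

Measured so far:
compound 1 `COc1ccc(-c2nnc(CCC(=O)c3ccc(C)cc3)o2)cc1OC` — 53.3%
compound 2 `COc1ccc(-c2nnc(CCC(=O)c3ccc(C)cc3C)o2)cc1OC` — 58.7%
compound 3 `Cc1ccc(C(=O)CCc2nnc(Cc3ccccc3)o2)cc1` — 24.7%

Three compounds have been run in a functional assay on the whole organism (strain Wistar) for inhibition, with Rattus norvegicus as the target, with stated times of 30 min and 2 h, at a dose of 20 mg/kg by the oral route; on this read-out lower numbers stand for less inhibition and higher numbers for more inhibition at the one dose given (going by the name of the read-out). Compound 1 gives 53.3% and compound 2 gives 58.7%; the two are related by one change, (methyl in place of hydrogen on an aromatic carbon), and the step of a number 5.4 percentage points higher from compound 1 to compound 2 (within the scatter) lies within the scatter, so the two values cannot be told apart. Compound 3 gives 24.7%, the lowest of the three numbers, with the gap to compound 1 and the gap to compound 2 both beyond the scatter. The difference between the core of compound 3 and the core of compound 1 is not broken down here.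

Compound 4 `Cc1ccc(C(=O)CCc2nnc(Cc3ccccc3)o2)c(C)c1` has not been measured. Going by the values given here, it differs from compound 3 by methyl in place of hydrogen on an aromatic carbon, which is the same change, at the same kind of place, as the one made from compound 1 to compound 2. Because the measured step of a number 5.4 percentage points higher from compound 1 to compound 2 (within the scatter) stayed within the scatter, the expected step of a number 4.3 percentage points higher from compound 3 to compound 4 (within the scatter) is likewise small and of uncertain sign. For compound 4 in this assay the estimated value is 29%, with a range from 14% to 45% that rests on compound 3 and on the single earlier occurrence of this change.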

Compound 4, a percentage reported as inhibition, in the whole organism at one dose (the size of the read-out at that dose, not a potency): 25.3%
The estimate for compound 4 lay 3.7 percentage points above the measured number; the range from low to high includes it.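

In this assay, the methyl that turns 4-methylphenyl into 2,4-dimethylphenyl gives a number 0.6 percentage points higher from compound 3 to compound 4 (within the scatter), so the two values cannot be told apart. The change reads the same on the two cores, and the two steps cannot be separated from each other: the same change on two cores in this assay, a number 5.4 percentage points higher (within the scatter) from compound 1 to compound 2 and a number 0.6 percentage points higher (within the scatter) from compound 3 to compound 4, 4.8 percentage points apart, within the scatter of two such steps. This shows that, on these two cores and at this one dose, the change carries over as a step too small to read, but it gives neither a reliable size nor a sign for the step, and two pairs do not establish that the same would hold on a further core in the series.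

The compounds shown leave open whether a different group in the same place, such as chlorine, an amine or a carboxylic acid, would give a step beyond the scatter on either core. Also open, going by these compounds, is which part of the difference between the core of compound 1 and the core of compound 3 goes with the gap between their values, and whether a longer chain in place of the one leading to the carbonyl would alter the number.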